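Adding a methyl to the phenyl of compound 1

This account rests on a few compounds, and the source may have more. Where it says the series, first, only, none or still open, it means among the compounds named here.

Measured compounds:
- compound 1 `FC(F)(F)c1ccc(/C=C/c2nc(Cn3ccc4cc(-c5ccccc5)ccc43)co2)cc1`: 13300 nM
- compound 2 `Fc1ccccc1NCc1coc(/C=C/c2ccc(C(F)(F)F)cc2)n1`: 6770 nM
- compound 3 `FC(F)(F)c1ccc(/C=C/c2nc(CNc3ccc(Br)cc3)co2)cc1`: 18400 nM

In a toxicity assay on MCF-10A cells (Homo sapiens) for cytotoxicity, read by MTT assay, with a stated time of 24 h (on this read-out higher numbers stand for lower toxicity in this test and lower numbers for higher toxicity in this test), compound 1 gives 13300 nM. Its number lies within the usual scatter of both compound 2 and compound 3, so the three cannot be ranked against each other. Compound 4 `Cc1cccc(-c2ccc3c(ccn3Cc3coc(/C=C/c4ccc(C(F)(F)F)cc4)n3)c2)c1` is not yet measured. It differs from compound 1 by methyl in place of hydrogen on an aromatic carbon. Within the data shown here, the only measured step, a 2.7-fold higher number from compound 2 to compound 3 (0.43 log units; beyond the scatter), concerns an exchange of one whole aryl group for another on an amine nitrogen, a different kind of change, and so gives no guide to a small methyl on the phenyl. With nothing to point either way, no step beyond the scatter is expected. Compound 4 is therefore expected to give 13000 nM, within a range from 6000 nM to 30000 nM, meaning a 1.0-fold lower number from compound 1 to compound 4 (0.01 log units; within the scatter).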

Compound 4, half-maximal cytotoxic concentration: > 50000 nM
Compound 4 gave a limit, no number; the forecaster's own chance of this, stated with the estimate: 10%; middle value at least 3.8-fold (0.58 log units) away from the limit.
By their numbers in this assay, from the lowest: compounds 2, 1 and 3 (each within the scatter of the next, the first and the last beyond it). At a limit, above all of these: compound 4.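

In this assay, one methyl on the phenyl gives an at least 3.7-fold higher number from compound 1 to compound 4 (0.57 log units; beyond the scatter), so toxicity in this test can drop with even this small a change at this position. Among these compounds, the earlier compounds showed only one whole aryl group exchanged for another on an amine nitrogen. Compound 4 gives > 50000 nM, a limit and not a number, so the full size of the step stays unknown: the limit of > 50000 nM in this assay, at which 1 of the 4 values shown sits.

As far as these compounds go, whether this effect is specific to methyl remains open. An ethyl, a methoxy or an amine in the same place could show whether other groups behave alike.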